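The source may hold more compounds than are shown below. What is called first, only, known or untested is meant among the compounds shown, and "the series" means these compounds.

Going by the values given here, compound 2 `N=C(N)NCc1cccc(Cl)c1` is the only member of the pair with a number in an in vitro assay on NG 108-15 cells for binding affinity to Serotonin 3 (5-HT3) receptor (Homo sapiens) (on this read-out higher numbers stand for weaker inhibition and lower numbers for stronger inhibition), where compound 2 gives 1200 nM. Compound 1 `NCCCCc1cccc(Cl)c1` sits at a limit of the assay rather than at a number: in this assay compound 1 gives > 10000 nM. Compound 3 `NCCCc1cccc(Cl)c1` carries a group of 3 heavy atoms (2 carbon, 1 nitrogen; no ring) in place of a group of 4 heavy atoms (1 carbon, 3 nitrogen; no ring), on a saturated chain carbon bound to an aromatic carbon. Among the compounds with values here, the one measured step, an at least 8.3-fold lower number from compound 1 to compound 2 (0.92 log units; beyond the scatter), ran the other way and started from the limit (the limit of > 10000 nM in this assay, at which 1 of the 2 values shown sits); removing the group that enters there is therefore expected to cost binding. Compound 3 is expected to show a 6.7-fold higher number from compound 2 to compound 3 (0.82 log units; beyond the scatter). Compound 3 is estimated at 8000 nM, range 2000 nM to 30000 nM, with a fair chance of another limit.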

Compound 3, inhibition constant: > 10000 nM
Compound 3 gave a limit, no number; the forecaster's own chance of this, stated with the estimate: 45%; middle value at least 1.2-fold (0.09 log units) away from the limit.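

In this assay, 2-aminoethyl entering on a saturated chain carbon bound to an aromatic carbon gives an at least 8.3-fold higher number from compound 2 to compound 3 (0.92 log units; beyond the scatter). The shorter amine chain therefore does not bring back a measurable number, and among the compounds shown only compound 2 keeps one. This step gives only a minimum size, and the step between compound 1 and compound 3 cannot be read, because these compounds sit at a limit: the limit of > 10000 nM in this assay, at which 2 of the 3 values shown sit.

As far as these compounds go, how far compound 1 and compound 3 lie beyond that limit remains open. Also open, from the compounds shown here alone, is whether an amidine or an aminomethyl group at this place would give a number.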